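The compounds below may be only part of what the source reports. "The series", "measured", "known", "first", "only" and "open" are said of these compounds alone.

Compound 1 `COc1ccc2c(c1)c(CCCC(=O)N1CCOCC1)c(C)n2Cc1ccccc1` stands lowest of the two measured compounds: in an assay on cells for inhibition of Polyunsaturated fatty acid 5-lipoxygenase (Rattus norvegicus), tested at 5 uM (a higher number here means more inhibition at the concentration tested (going by the name of the read-out), a lower number less inhibition), compound 1 gives 54.2%, while compound 2 `COc1ccc2c(c1)c(CCCC(=O)N1CCOCC1)c(C)n2C(=O)c1ccc(Cl)cc1` gives 70.2%. For the measured compounds named here, the only measured step, a number 16 percentage points higher from compound 1 to compound 2 (beyond the scatter), alters the group on the aromatic nitrogen. Compound 3 `COc1ccc2c(c1)c(CCCC(=O)N1CCNCC1)c(C)n2Cc1ccccc1` differs from compound 1 at another place: piperazin-1-yl in place of morpholin-4-yl on a carbonyl carbon. Going by the values given here, no measured step touches this part of the molecule, so the data give no guide to the size or direction of the change. The expected step is therefore a number 2.2 percentage points lower from compound 1 to compound 3 (within the scatter), within the usual scatter. Compound 3 is estimated at 52%, between 30% and 72%.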

Compound 3, a percentage reported as inhibition, at one concentration (the size of the read-out at that concentration, not a potency): 64.6%
Beside the measured number, compound 3's estimate is 12.6 percentage points below it, within the range that was stated.
By their numbers in this assay, from the lowest: compound 1; then compounds 3 and 2 (each within the scatter of the next).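

In this assay the group on the carbonyl carbon matters: a number 10.4 percentage points higher from compound 1 to compound 3 (beyond the scatter) comes with piperazin-1-yl in place of morpholin-4-yl. The ring stays six-membered, but its oxygen gives way to a nitrogen that carries a hydrogen-bond donor. Nothing measured here explains the step. Open, as far as these compounds go, is how a piperidin-1-yl or 4-methylpiperazin-1-yl group would read on the same carbonyl carbon, which would test that ring nitrogen and its hydrogen. Also open, from the compounds shown here alone, is whether the step holds with (4-chlorophenyl)carbonyl on the aromatic nitrogen.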